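Estimating clearance after a change in one ring group

The compounds below may be only part of what the source reports. "The series", "measured", "known", "first", "only" and "open" are said of these compounds alone.

In an ADME assay on the whole organism (Mus musculus, strain CD-1) for pharmacokinetics (a higher number here means faster removal of the compound, a lower number slower removal), compound 1 `CCOc1cc([C@](O)(CCN(C)C)[C@@H](c2cc3cc(Br)ccc3nc2OC)c2cccc(OC)c2F)cc(OC)n1` gives 19 mL/min/kg and compound 2 `CCOc1cc([C@](O)(CCN(C)C)[C@@H](c2cc3cc(Br)ccc3nc2OC)c2ccnc(OC)c2OC)cc(OC)n1` gives 9.5 mL/min/kg, so the two cannot be told apart. Compound 3 `COc1cccc([C@H](c2cc3cc(Br)ccc3nc2OC)[C@@](O)(CCN(C)C)c2cc(SC)nc(SC)c2)c1F` differs from compound 1 by a group of 10 heavy atoms (7 carbon, 1 nitrogen, 2 sulfur; one six-membered aromatic ring with 1 hetero atom) in place of a group of 11 heavy atoms (8 carbon, 1 nitrogen, 2 oxygen; one six-membered aromatic ring with 1 hetero atom), on a saturated chain carbon bound to an oxygen on a saturated carbon and two saturated chain carbons on a saturated chain carbon bound to an oxygen on a saturated carbon and two saturated chain carbons. Going by the values given here, the only measured step is a 2.0-fold lower number from compound 1 to compound 2 (0.30 log units; within the scatter) and lies within the scatter, but it concerns another group and offers only a weak guide. No shift beyond the scatter is expected in this assay, and the expected step is a 1.1-fold lower number from compound 1 to compound 3 (0.05 log units; within the scatter) in size. Compound 3 is estimated at 17 mL/min/kg with a range from 7 mL/min/kg to 42 mL/min/kg for now.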

Compound 3, clearance: 13 mL/min/kg
Compound 3: middle estimate off by 1.3-fold (0.12 log units), on the high side; low and high end bracket the measured number.
By their numbers in this assay, from the lowest: compounds 2, 3 and 1 (each within the scatter of the next).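

In this assay, putting the group of 10 heavy atoms with 2 sulfur in place of the group of 11 heavy atoms with 2 oxygen gives a 1.5-fold lower number from compound 1 to compound 3 (0.16 log units; within the scatter), so the two compounds cannot be told apart. Going by these compounds alone, this is the first reading at this position, on a saturated chain carbon bound to an oxygen on a saturated carbon and two saturated chain carbons, and this exchange is tolerated without a clear shift. No measurement at hand offers an explanation for this result. Still open, as far as these compounds go, is whether a group carrying an amine or a carboxylic acid at this position would give a step beyond the scatter.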